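Benzyl for cyclopropyl on the ring sulfonamide nitrogen

A few compounds are considered here, and "the series" means these few. Any claim that something is new, unique, unknown or untested is made for them only; others in the source may bear on it.

Measured in an assay on isolated protein for inhibition of Aromatase (Homo sapiens), tested at 1 uM; on this read-out higher numbers stand for more inhibition at the one concentration tested (going by the name of the read-out) and lower numbers for less inhibition:
compound 1 `CC(C)CC1n2cncc2CN(CC2CC2)S1(=O)=O` gives 19%
compound 2 `CC(C)CC1n2cncc2CN(Cc2ccc(OC(F)(F)F)cc2)S1(=O)=O` gives 13%
compound 3 `CC(C)CC1n2cncc2CN(C2CC2)S1(=O)=O` gives 9%

Compound 3 holds the lowest of the three numbers, yet its gaps to compound 2 and to compound 1 both fall within the scatter, so no order among the three is established. Within the data shown here, the single one-place step known is a number 10 percentage points lower from compound 1 to compound 3 (within the scatter).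

Compound 4 `CC(C)CC1n2cncc2CN(Cc2ccccc2)S1(=O)=O` differs from compound 3 by benzyl in place of cyclopropyl on a sulfonamide nitrogen in a ring. Among the measured compounds shown here, no measured step replaces a cyclopropyl by a benzyl; the nearest relative is compound 2, also bearing a benzyl-type group, at its value above. The expectation is therefore no step beyond the scatter, a number 5 percentage points higher from compound 3 to compound 4 (within the scatter), and for compound 4 in this assay an estimated 14%, range 2% to 28%.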

Compound 4, a percentage reported as inhibition, at one concentration (the size of the read-out at that concentration, not a potency): 14%
Estimate against measurement, compound 4: no gap at the digits printed; measured number inside the range.
By their numbers in this assay, from the lowest: compounds 3, 2, 4 and 1 (each within the scatter of the next).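

In this assay the change on the sulfonamide nitrogen gives a number 5 percentage points higher from compound 3 to compound 4 (within the scatter) and a number 5 percentage points lower from compound 1 to compound 4 (within the scatter) at the one concentration tested. Losing the trifluoromethoxy from the aromatic carbon gives a number 1 percentage points higher from compound 2 to compound 4 (within the scatter) as well, so at this position neither benzyl nor its substituted form separates from cyclopropyl or cyclopropylmethyl. Nothing at hand bears on why these numbers lie so close.

As far as these compounds go, whether an amine or a carboxylic acid on the benzyl ring, or a longer chain on the sulfonamide nitrogen, would give a step beyond the scatter remains open.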